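The compounds below may be only part of what the source reports. "The series", "measured", "known", "first", "only" and "open" are said of these compounds alone.

Compound 1 `Cc1ccc2oc(SCC(=O)Nc3ccc(-c4nc(-c5ccccc5)c(-c5ccccc5)n4C)cc3)nc2c1`: 57.7%
Compound 2 `Cn1ccnc1SCC(=O)Nc1ccc(-c2nc(-c3ccccc3)c(-c3ccccc3)n2C)cc1`: 43.4%

In a functional assay on MCF7 cells (Homo sapiens) for cytotoxicity, read by MTT assay, with a stated time of 24 h, tested at 32 ug/mL (on this read-out lower numbers stand for a weaker effect and higher numbers for a stronger effect at the one concentration tested), compound 2 stands lowest of the two numbers shown, with compound 1 its only neighbour; the single measured step, a number 14.3 percentage points lower from compound 1 to compound 2 (beyond the scatter), separates them and is modest, though beyond the scatter. Compound 3 `CN1CCN(CC(=O)Nc2ccc(-c3nc(-c4ccccc4)c(-c4ccccc4)n3C)cc2)CC1` has not yet been measured. It differs from compound 2 by 4-methylpiperazin-1-yl in place of (1-methyl-1H-imidazol-2-yl)sulfanyl on a saturated chain carbon bound to a carbonyl carbon. Among the compounds with values here, the one measured step concerned only the ring carried on the sulfur; here the sulfanyl group itself leaves and a six-membered non-aromatic ring enters on the chain carbon bound to the carbonyl, so no measured step bears directly on this change. Given that the only known step was modest, a step of similar or smaller size is expected in this assay, direction uncertain, and it may not exceed the scatter: a number 3.4 percentage points lower from compound 2 to compound 3 (within the scatter) is the estimated step. Compound 3 is therefore expected to give about 40%, between 22% and 58%.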

Compound 3, a percentage reported as activity, at one concentration (the size of the read-out at that concentration, not a potency): 46.2%
For compound 3 the middle estimate is 6.2 percentage points below the measured one; low and high end bracket the measured number.
By their numbers in this assay, from the lowest: compounds 2 and 3 (each within the scatter of the next); then compound 1.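

In this assay a group with no sulfur, 4-methylpiperazin-1-yl, on a saturated chain carbon bound to a carbonyl carbon gives a number 2.8 percentage points higher from compound 2 to compound 3 (within the scatter) and so cannot be told apart from the (1-methyl-1H-imidazol-2-yl)sulfanyl group at this position. Set against the (5-methyl-1,3-benzoxazol-2-yl)sulfanyl group, the same change gives a number 11.5 percentage points lower from compound 1 to compound 3 (beyond the scatter) and so leaves compound 1 with the highest number of the three, beyond the scatter of both others. No measurement offered here explains either step.

On these data alone, whether a morpholin-4-yl group or an open-chain dimethylamino group on the same chain carbon would read like compound 3 remains open. As far as these compounds go, it is also open whether a longer chain between the carbonyl and the 4-methylpiperazin-1-yl group would alter the read-out.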